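The source may hold more compounds than are shown below. What is called first, only, known or untested is meant among the compounds shown, and "the series" means these compounds.

Of the compounds shown here, three sharing one core have been measured in an assay for inhibition of acid-sensing ion channel 3 (Homo sapiens), read by patch clamp, tested at 1 uM; on this read-out higher numbers stand for more inhibition at the one concentration tested (going by the name of the read-out) and lower numbers for less inhibition. Compound 1 `NC(N)=NC(=O)c1nc(Cl)c(NC2CCCCC2)nc1N` gives 21%, compound 2 `CCCN(C)c1nc(N)c(C(=O)N=C(N)N)nc1Cl` gives 32%, and compound 3 `COc1nc(N)c(C(=O)N=C(N)N)nc1Cl` gives 21%. Compound 3 thus stands level with compound 1, the two together forming the low end of the three numbers, with the step of a number 11 percentage points lower from compound 2 to compound 3 (beyond the scatter) the only movement beyond the scatter.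

Compound 4 `NC(N)=NC(=O)c1nc(Cl)c(Sc2ccccc2)nc1N` differs from compound 3 in one place: phenylsulfanyl in place of methoxy on an aromatic carbon. The measured steps at this same carbon, no change at the digits printed from compound 1 to compound 3 (within the scatter) and a number 11 percentage points lower from compound 2 to compound 3 (beyond the scatter), were small or absent, and no group resembling phenylsulfanyl has been measured, so the direction is uncertain. A modest rise is expected, a number 9 percentage points higher from compound 3 to compound 4 (within the scatter). Compound 4 is therefore estimated at 30%, within 10% to 50%.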

Compound 4, a percentage reported as inhibition, at one concentration (the size of the read-out at that concentration, not a potency): 11%
Compound 4: middle estimate off by 19 percentage points, on the high side, and the stated range covers the measured number.
By their numbers in this assay, from the lowest: compounds 4, 1 and 3 (each within the scatter of the next); then compound 2.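

Phenylsulfanyl is the first group shown at this carbon that is joined through sulfur and carries an aromatic ring, and it gives a number 21 percentage points lower from compound 2 to compound 4 (beyond the scatter) as its one step beyond the scatter. Its other two steps are a number 10 percentage points lower from compound 3 to compound 4 (within the scatter) and a number 10 percentage points lower from compound 1 to compound 4 (within the scatter) so compound 4 cannot be separated from compound 3 or compound 1. No available evidence bears on this result.

The compounds shown leave open whether the sulfur or the aromatic ring accounts for the gap to compound 2. A phenylamino group, with nitrogen in place of sulfur, and a methylsulfanyl group, with sulfur but no ring, would help separate the two.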